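The compounds below may be only part of what the source reports. "The series", "measured", "known", "first", "only" and "open" are said of these compounds alone.

Three compounds of one series have so far been examined in an assay on cells for inhibition of Voltage-dependent T-type calcium channel subunit alpha-1H (Homo sapiens), read by FLIPR and calcium flux, with stated times of 600 s and 300 s; on this read-out higher numbers stand for weaker inhibition and lower numbers for stronger inhibition. Compound 1 `CN(Cc1ccc(OCCCNC(=N)N)cc1)c1nc2ccc(Oc3ccc(F)cc3)cc2s1` gives 521000 nM in this assay. Compound 2 `CN(Cc1ccc(OCCCNC(=N)N)cc1)c1nc2ccc(Oc3cccc(C(F)(F)F)c3)cc2s1` differs from compound 1 by 3-(trifluoromethyl)phenyl in place of 4-fluorophenyl on an oxygen on an aromatic ring; in this assay compound 2 gives 771000 nM, and the step is a 1.5-fold higher number from compound 1 to compound 2 (0.17 log units; within the scatter). Compound 3 `NCCCOc1ccc(CNc2nc3ccc(Oc4ccc(F)cc4)cc3s2)cc1` carries another core, and the difference between the core of compound 1 and the core of compound 3 is not broken down here. In this assay compound 3 gives 688000 nM, a number that lies within the scatter of both compound 1 and compound 2, so no order among the three can be read from these values.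

Compound 4 `NCCCOc1ccc(CNc2nc3ccc(Oc4cccc(C(F)(F)F)c4)cc3s2)cc1` has not yet been measured. It differs from compound 3 by 3-(trifluoromethyl)phenyl in place of 4-fluorophenyl on an oxygen on an aromatic ring, the same change that was made from compound 1 to compound 2, at a place described in the same words. For compound 4 the expected step is a 1.3-fold higher number from compound 3 to compound 4 (0.12 log units; within the scatter), resting on a 1.5-fold higher number from compound 1 to compound 2 (0.17 log units; within the scatter) having stayed within the scatter. The estimated value of compound 4 in this assay is 900000 nM, with a likely range from 450000 nM to 1800000 nM.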

Compound 4, half-maximal inhibitory concentration: 171000 nM
Compound 4: middle estimate off by 5.3-fold (0.72 log units), on the high side, outside the stated range (below it).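

In this assay, 3-(trifluoromethyl)phenyl in place of 4-fluorophenyl on an oxygen on an aromatic ring gives a 4.0-fold lower number from compound 3 to compound 4 (0.60 log units; beyond the scatter), and this does not match what the same change did on the core of compound 1: the same change on two cores in this assay, a 1.5-fold higher number (0.17 log units; within the scatter) from compound 1 to compound 2 and a 4.0-fold lower number (0.60 log units; beyond the scatter) from compound 3 to compound 4, 6.0-fold (0.77 log units) apart, beyond the scatter of two such steps. In this series, then, the effect of this change did not carry from one core to the other, and the step measured on the core of compound 1 gave no reliable reading of the step on the core of compound 3. This rests on a single pair of steps, however, and it does not show which part of the difference between the two cores is responsible, nor why the steps part.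

The compounds shown leave open whether other groups on the oxygen, such as a phenyl bearing a nitrile or a chlorine, would also behave differently on the two cores. They also leave open how a carboxylic acid in place of the amine of compound 3, or a longer chain, would affect the step.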